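Swapping Methoxy for Fluorine on the Aniline Ring

The source may hold more compounds than are shown below. What is called first, only, known or untested is meant among the compounds shown, and "the series" means these compounds.

Measured in a functional assay on A549 cells (Homo sapiens) for cytotoxicity, read by MTT assay, with a stated time of 48 h; on this read-out lower numbers stand for stronger inhibition and higher numbers for weaker inhibition:
Compound 1, `Cc1ccc(S(=O)(=O)/N=C(/CCNC2=CC(=O)c3ccccc3C2=O)Nc2ccc(Cl)cc2)cc1`, gives 29900 nM.
Compound 2, `Cc1ccc(S(=O)(=O)/N=C(/CCNC2=CC(=O)c3ccccc3C2=O)Nc2cccc(C(F)(F)F)c2)cc1`, gives 78500 nM.
Compound 3, `COc1ccc(N/C(CCNC2=CC(=O)c3ccccc3C2=O)=N\S(=O)(=O)c2ccc(C)cc2)cc1OC`, gives 20500 nM.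

Going by the values given here, compound 3 has the lowest number of the three, though its gap to compound 1 is within the scatter; only the step of a 3.8-fold lower number from compound 2 to compound 3 (0.58 log units; beyond the scatter) is beyond it. Compound 4, `Cc1ccc(S(=O)(=O)/N=C(/CCNC2=CC(=O)c3ccccc3C2=O)Nc2ccc(F)c(F)c2)cc1`, changes one place: 3,4-difluorophenyl in place of 3,4-dimethoxyphenyl on an amine nitrogen. Among the compounds with values here, the steps that bear on this change are a 1.5-fold lower number from compound 1 to compound 3 (0.16 log units; within the scatter) and a 2.6-fold higher number from compound 1 to compound 2 (0.42 log units; beyond the scatter), both modest. Compound 1, with its 4-chlorophenyl group, is the closest relative of compound 4, so a small rise in this assay is expected, a 1.6-fold higher number from compound 3 to compound 4 (0.19 log units; within the scatter). Compound 4 is therefore estimated at 32000 nM, within 15000 nM to 70000 nM.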

Compound 4, half-maximal inhibitory concentration: 16700 nM
The estimate for compound 4 lay 1.9-fold (0.28 log units) above the measured number, within the range that was stated.
By their numbers in this assay, from the lowest: compounds 4, 3 and 1 (each within the scatter of the next); then compound 2.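

In this assay, placing 3,4-difluorophenyl instead of 3,4-dimethoxyphenyl on this amine nitrogen gives a 1.2-fold lower number from compound 3 to compound 4 (0.09 log units; within the scatter), and replacing 4-chlorophenyl gives a 1.8-fold lower number from compound 1 to compound 4 (0.25 log units; within the scatter), so compounds 1, 3 and 4 cannot be told apart here. Only compound 2, with its 3-(trifluoromethyl)phenyl group, stands apart, with a 4.7-fold lower number from compound 2 to compound 4 (0.67 log units; beyond the scatter). Nothing available here explains that gap. The compounds shown leave open whether an amine or a carboxylic acid on this ring, or a simple alkyl chain in place of the ring, would move the number beyond the scatter.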